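The source may report more compounds than this note shows. Statements on the series, on what has been measured and on what is new or still open speak of the compounds shown alone.

Compound 1 `COc1ccc(C(=O)c2cc(OC)c(OC)c(OC)c2)cc1N` is the parent of the pair, and in a functional assay on HeLa cells (Homo sapiens) for cytotoxicity, read by MTT assay, with a stated time of 72 h (on this read-out higher numbers stand for weaker inhibition and lower numbers for stronger inhibition), compound 1 gives 60 nM. Going by the values given here, compound 2 `COc1ccc(/C=C/C(=O)Nc2cc(C(=O)c3cc(OC)c(OC)c(OC)c3)ccc2OC)cc1` carries an amide-linked arm ending in a 2-(4-methoxyphenyl)ethenyl group on the amine of that core, and in this assay compound 2 gives 10700 nM, the higher of the two numbers known so far, with compound 1 standing at the lower one. Compound 3 `COc1ccc(C(=O)c2cc(OC)c(OC)c(OC)c2)cc1NC(=O)/C=C/c1ccc(C(F)(F)F)cc1` differs from compound 2 in a single place: trifluoromethyl in place of methoxy on an aromatic carbon. Among the compounds with values here, no pair of measured compounds shows the effect of such an exchange, so the size of the step cannot be read from the data. The amide, the ethenyl linker and the core stay untouched, and a change within the usual scatter, or at most a small one in either direction, is expected. The expected step is a 1.2-fold lower number from compound 2 to compound 3 (0.08 log units; within the scatter), because compound 2 already gives 10700 nM and the exchange touches only the outer ring. The estimate for compound 3 in this assay is 9000 nM, within a range from 3000 nM to 30000 nM.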

Compound 3, half-maximal inhibitory concentration: 90 nM
For compound 3 the middle estimate is 100-fold (2.00 log units) above the measured one; the measured number lies below the stated range.
By their numbers in this assay, from the lowest: compounds 1 and 3 (each within the scatter of the next); then compound 2.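

In this assay the exchange of methoxy for trifluoromethyl on the outer ring, on an aromatic carbon para to a large group, gives a 120-fold lower number from compound 2 to compound 3 (2.08 log units; beyond the scatter) and so shows that the reading of this series depends heavily on the group at this one position, something the first two compounds could not reveal. Taken alone, those two compounds left open the reading that the arm on the amine costs the activity, yet compound 3 keeps the same amide and ethenyl linker and gives 90 nM in this assay, within the scatter of compound 1 at 60 nM and so without any order between the two. Nothing at hand gives a reason for the size of this step.

With only methoxy and trifluoromethyl shown at this position, it stays open whether a plain hydrogen, a chlorine or a nitrile there would read like compound 2, like compound 3 or somewhere in the wide span between them. As far as these compounds go, it also stays open whether the trifluoromethyl result would survive if the ethenyl linker gave way to a saturated ethyl chain.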